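Dimethoxyphenyl for Dichlorophenyl on the Ketone Arm

The source may report more compounds than this note shows. Statements on the series, on what has been measured and on what is new or still open speak of the compounds shown alone.

Measured compounds:
compound 1 `COc1ccc(-c2cc(/C=C/C(=O)c3ccc(OC)c(OC)c3)[nH]n2)cc1`: 57600 nM
compound 2 `COc1cc(-c2cc(/C=C/C(=O)c3ccc(Cl)c(Cl)c3)[nH]n2)cc(OC)c1OC`: > 100000 nM
compound 3 `COc1ccc(-c2cc(/C=C/C(=O)c3ccc(N)cc3)[nH]n2)cc1OC`: 39000 nM

Of the compounds shown here, three of the shared core have been tested in a functional assay on OVCAR-8 cells (Homo sapiens) for inhibition, read by sulforhodamine B assay, with a stated time of 48 h; a higher number here means that more compound is tolerated, a lower number that less compound is tolerated. In this assay compound 1 gives 57600 nM. Compound 3 gives 39000 nM in this assay, and these two numbers lie within the usual scatter of each other, so no order between them is claimed. Compound 2 stands apart: its result of > 100000 nM is a limit of this assay and not a number. Compound 2 thus sits at the limit of > 100000 nM in this assay, at which 1 of the 3 values shown sits, and nothing more than this limit is known of where it lies.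

Compound 4 `COc1ccc(C(=O)/C=C/c2cc(-c3cc(OC)c(OC)c(OC)c3)n[nH]2)cc1OC` has not yet been measured. It differs from compound 2 in one place: 3,4-dimethoxyphenyl in place of 3,4-dichlorophenyl on a carbonyl carbon. Within the data shown here, no measured step connects two compounds that differ in one place, so the expectation for compound 4 rests on the observation that compound 1 and compound 3, both carrying methoxy-bearing aryl groups on the carbonyl carbon, give numbers rather than limits. The step from an at least 2.0-fold lower number from compound 2 to compound 4 (0.30 log units; that floor lies within the scatter) is therefore expected to run downward, toward a number below the limit, beyond the scatter, though its size cannot be fixed while compound 2 is known only as a limit. Compound 4 is estimated at 50000 nM, with a range from 20000 nM to 100000 nM.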

Compound 4, concentration lethal to 50% of the cells: 5640 nM
Compound 4: the middle estimate sits 8.9-fold (0.95 log units) above what was measured, and the stated range ends above it.
By their numbers in this assay, from the lowest: compound 4; then compounds 3 and 1 (each within the scatter of the next). At a limit, above all of these: compound 2.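

Among these compounds, until this result, no two measured compounds differed in only one place, so the effect of a change on the carbonyl carbon could not be read directly. In this assay, placing 3,4-dimethoxyphenyl where 3,4-dichlorophenyl stood gives an at least 17-fold lower number from compound 2 to compound 4 (1.24 log units; beyond the scatter), which shows that the aryl group at this position can by itself shift the read-out well beyond the scatter. On these data alone, the true size of the step remains unknown, as the result for compound 2 is a limit and not a number: the limit of > 100000 nM in this assay, at which 1 of the 4 values shown sits.

The compounds shown do not reveal which feature of the exchange matters, or whether another group on this aryl ring, such as a nitrile or a carboxylic acid, would give a similar result. Among the compounds shown here, because this single pair is the only direct comparison, they also leave open whether the same exchange would have a step of similar size if another part of the shared core were different.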